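Changing the Amide Aryl Group on a Shared Core

The compounds below may be only part of what the source reports. "The series", "measured", "known", "first", "only" and "open" are said of these compounds alone.

The measured compounds:
Compound 1, `COc1ccc(Cl)cc1C(=O)Nc1nc(-c2ccccc2)nc2c1nnn2Cc1ccccc1`, 7150 nM
Compound 2, `O=C(Nc1nc(-c2ccccc2)nc2c1nnn2Cc1ccccc1)c1cccc([N+](=O)[O-])c1`, 77 nM
Compound 3, `O=C(Nc1nc(-c2ccccc2)nc2c1nnn2Cc1ccccc1)C1CCCC1`, 2.5 nM

In an assay (strain Wistar) for displacement of a labelled ligand from adenosine receptor A1 (Rattus norvegicus), read by scintillation counting (a higher number here means a weaker inhibitor, a lower number a stronger inhibitor), compound 1 gives the highest of the three numbers. Its nearest neighbour is compound 2, reached by a 93-fold lower number from compound 1 to compound 2 (1.97 log units; beyond the scatter), and the furthest is compound 3, reached by a 2900-fold lower number from compound 1 to compound 3 (3.46 log units; beyond the scatter); between those two, a 31-fold lower number from compound 2 to compound 3 (1.49 log units; beyond the scatter) completes the picture.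

Compound 4, `O=C(Nc1nc(-c2ccccc2)nc2c1nnn2Cc1ccccc1)c1ccccc1F`, has not yet been measured. It differs from compound 1 by 2-fluorophenyl in place of 5-chloro-2-methoxyphenyl on a carbonyl carbon. Among the compounds with values here, the one measured step that keeps an aromatic ring on the carbonyl carbon is the step from compound 1 to compound 2, where a differently substituted phenyl ring brought a large drop in the number. The step to compound 3 shows that leaving the aromatic ring altogether went further still, but compound 4 keeps its ring, so the step to compound 2 is the closer guide.

Compound 4 is therefore expected to show a 60-fold lower number from compound 1 to compound 4 (1.78 log units; beyond the scatter), a lower number than compound 1, probably of a size comparable to that seen for compound 2. The estimate for compound 4 is 120 nM, with a range from 15 nM to 900 nM.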

Compound 4, inhibition constant: 40 nM
Beside the measured number, compound 4's estimate is 3.0-fold (0.48 log units) above it; measured number inside the range.
By their numbers in this assay, from the lowest: compound 3; then compounds 4 and 2 (each within the scatter of the next); then compound 1.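

With a 180-fold lower number from compound 1 to compound 4 (2.25 log units; beyond the scatter) in this assay, the result shows that an aromatic ring on the carbonyl carbon is compatible with a low number, so the high number of compound 1 goes with its 5-chloro-2-methoxyphenyl group and not with aromatic amides in general. Among the aromatic amides with low numbers, the two groups cannot be told apart, with a 1.9-fold lower number from compound 2 to compound 4 (0.28 log units; within the scatter), while a 16-fold higher number from compound 3 to compound 4 (1.20 log units; beyond the scatter) leaves the cyclopentyl amide clearly lowest. Nothing available explains these differences.

On these data alone, it remains open whether the chlorine, the methoxy group or the two together go with the high number of compound 1. Also open, as far as these compounds go, is how an unsubstituted phenyl ring, a 2-methoxyphenyl ring or a cyclohexyl ring would read on the same carbonyl carbon.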